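A few compounds are considered here, and "the series" means these few. Any claim that something is new, unique, unknown or untested is made for them only; others in the source may bear on it.

Compound 1 `CCOC(=O)c1cc(-c2cccc(OCc3cccc(C)c3)c2)on1` — in an ADME assay on Vero cells (Chlorocebus sabaeus) for cytotoxicity, with a stated time of 72 h (a lower number here means a stronger inhibitor, a higher number a weaker inhibitor), compound 1 gives > 128000 nM, which is a limit of the assay.
Compound 2 `CCOC(=O)c1cc(-c2cccc(OCc3ccc(F)cc3F)c2)on1` — in this assay compound 2 gives > 128000 nM, likewise a limit.
Compound 3 `CCOC(=O)c1cc(-c2cccc(OCc3cc(F)ccc3Cl)c2)on1` — in this assay compound 3 gives "not determined" (no result reported).

Compound 3 therefore stands without a number of its own, and the two values beside it both sit at the limit of > 128000 nM in this assay, at which 2 of the 3 values shown sit. Compound 4 `CCOC(=O)c1cc(-c2cccc(OCc3ccc(F)c(F)c3F)c2)on1` differs from compound 3 by 2,3,4-trifluorophenyl in place of 2-chloro-5-fluorophenyl on a saturated chain carbon bound to an oxygen on an aromatic ring. Going by the values given here, the only measured step, a step that the two limits leave unreadable from compound 1 to compound 2, also exchanges one group at that chain carbon for another, yet its size cannot be read, so no direction or size can be drawn from it. Compound 4 is expected to show weak cytotoxicity, around 128000 nM, in the range 60000 nM to 250000 nM, most probably reported again only as a limit.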

Compound 4, half-maximal inhibitory concentration: > 128000 nM
Compound 4 gave a limit, no number; the forecaster's own chance of this, stated with the estimate: 75%; the middle value sits exactly at the limit.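

No step can be read among compound 1, compound 2 and compound 4, because each result is a limit and not a number: the limit of > 128000 nM in this assay, at which 3 of the 4 values shown sit.

The compounds shown leave open whether changing the aromatic ring on the chain carbon alters the result in this assay at all.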